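From propoxy to (methylsulfanyl)methoxy on a shared core

The source may hold more compounds than are shown below. What is called first, only, known or untested is meant among the compounds shown, and "the series" means these compounds.

Of the compounds shown here, three sharing a core have been measured in a functional assay on a cell-free system (plasma, Homo sapiens) for inhibition, with Plasma (Rattus norvegicus) as the target (a higher number here means a weaker inhibitor, a lower number a stronger inhibitor), and their numbers spread widely. Compound 2 (`CCCOc1ccc2c(N3CCNCC3)cc(=O)oc2c1C`) reads 7770 nM and is the strongest inhibitor of the three. Compound 3 (`O=c1cc(N2CCNCC2)c2ccc(OCc3cccnc3)cc2o1`) gives 18900 nM and compound 1 (`O=c1cc(N2CCNCC2)c2c(OCc3ccccc3)cccc2o1`) gives 429000 nM in the same test, both beyond the scatter from compound 2.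

Compound 4 (`CSCOc1ccc2c(N3CCNCC3)cc(=O)oc2c1C`) alters compound 2 in one place only: methylsulfanyl in place of ethyl on a saturated chain carbon bound to an oxygen on an aromatic ring. Among the compounds with values here, no measured pair shows this change, so there is no direct precedent for it. Within the data shown here, the expectation leans on compound 2 at 7770 nM as the one close neighbour, and only a slight rise in this assay is foreseen, with nothing beyond the scatter. The expected step of a 1.2-fold higher number from compound 2 to compound 4 (0.06 log units; within the scatter) is therefore small. Compound 4 is estimated at 9000 nM with a range from 3500 nM to 25000 nM when it is measured.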

Compound 4, half-maximal inhibitory concentration: 3400 nM
Beside the measured number, compound 4's estimate is 2.6-fold (0.42 log units) above it; measured number below the stated range.
By their numbers in this assay, from the lowest: compound 4; then compound 2; then compound 3; then compound 1.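

In this assay, replacing ethyl with methylsulfanyl on a saturated chain carbon bound to an oxygen on an aromatic ring gives a 2.3-fold lower number from compound 2 to compound 4 (0.36 log units; beyond the scatter) and so shows that this place responds to the change, even though the group keeps the same count of heavy atoms. The earlier compounds shown here could not show this, as no two of them differed in one place only. No measurement at hand accounts for this step.

On these data alone, whether a longer chain such as butoxy, or methoxymethoxy with oxygen where the sulfur stands, would move the number in the same way remains open. This single step also cannot say whether methylsulfanyl in place of ethyl would read alike on a chain carried by the cores of compound 1 or compound 3.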